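A methyl for chloro swap at low growth inhibition

The source may report more compounds than this note shows. Statements on the series, on what has been measured and on what is new or still open speak of the compounds shown alone.

Of the compounds shown here, three on a shared core have so far been read in a functional assay on NCI-H460 cells (Homo sapiens) for inhibition, read by MTT assay, with a stated time of 24 h, tested at 1 ug/mL (on this read-out lower numbers stand for less inhibition of growth and higher numbers for more inhibition of growth at the one concentration tested), at the one concentration tested. Compound 1 `O=C(CCCCC(S)CCS)Nc1ccccc1` gives 4.3% while compound 2 `O=C(CCCCC(S)CCS)Nc1cccc(Cl)c1` gives 7.2% and compound 3 `O=C(CCCCC(S)CCS)Nc1ccc([N+](=O)[O-])c(C(F)(F)F)c1` gives 6.29% on this measure. Compound 2 stands within the scatter of both others, so these numbers offer no ranking.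

Compound 4 `Cc1cccc(NC(=O)CCCCC(S)CCS)c1` differs from compound 2 by a single change methyl in place of chloro on an aromatic carbon that puts methyl in place of chloro on an aromatic carbon. Within the data shown here, the only measured step bearing on this is a number 2.9 percentage points higher from compound 1 to compound 2 (within the scatter) for chloro in place of hydrogen on an aromatic carbon, and it stays within the scatter. Among the measured compounds shown here, no measured compound carries methyl, so the data give no direct reading of that group. A step beyond the scatter is therefore not expected in this assay and no direction is favoured. The expected step is a number 1.2 percentage points lower from compound 2 to compound 4 (within the scatter) as an estimate only. Compound 4 is estimated at 6% with an expected range from 0% to 15% as its likely span.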

Compound 4, percent growth inhibition at one concentration: 9.43%
Estimate against measurement, compound 4: 3.4 percentage points below; the range from low to high includes it.
By their numbers in this assay, from the lowest: compounds 1, 3, 2 and 4 (each within the scatter of the next).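

In this assay the swap of chloro for methyl on this aromatic carbon, meta to a large group, gives a number 2.2 percentage points higher from compound 2 to compound 4 (within the scatter) and so does not separate the two groups. Methyl in place of hydrogen gives a number 5.1 percentage points higher from compound 1 to compound 4 (within the scatter) and thus adds what the earlier compounds could show only for chloro: neither group, each of one heavy atom, moves the read-out beyond the scatter from the unsubstituted compound 1 at the one concentration tested. No measured evidence bears on the reason for these numbers.

On these data alone, it remains open whether an amine, a carboxylic acid or a longer chain on this carbon would give a step beyond the scatter. The compounds shown also leave open whether methyl and chloro would read alike on the other carbons of this ring.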